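The source may hold more compounds than are shown below. What is called first, only, known or untested is meant among the compounds shown, and "the series" means these compounds.

Measured so far in an ADME assay on L02 cells (Homo sapiens) for cytotoxicity, read by MTT assay, with a stated time of 24 h; on this read-out lower numbers stand for stronger inhibition and higher numbers for weaker inhibition:

compound 1, `COc1cc(/C=C2\CN(C)C/C(=C\c3ccccc3F)C2=O)cc(OC)c1`: 11900 nM
compound 2, `CN1C/C(=C\c2ccc(C#N)cc2)C(=O)/C(=C/c2ccccc2F)C1`: 11000 nM
compound 3, `COc1cc(/C=C2\CN(C)C/C(=C\c3ccc(F)cc3)C2=O)cc(OC)c1`: 21900 nM

Compound 1 and compound 3 share a core and differ only by 4-fluorophenyl in place of 2-fluorophenyl on a double-bonded chain carbon bound to a double-bonded ring carbon. In this assay the change yields a 1.8-fold higher number from compound 1 to compound 3 (0.26 log units; within the scatter), so the two compounds cannot be separated on this read-out. Compound 2 carries a different core; the difference between the core of compound 1 and the core of compound 2 is not broken down here. In this assay compound 2 gives 11000 nM, which sits within the scatter of both compound 1 and compound 3, so no ordering among the three is supported.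

Compound 4, `CN1C/C(=C\c2ccc(F)cc2)C(=O)/C(=C/c2ccc(C#N)cc2)C1`, has not yet been measured in this assay. It differs from compound 2 by 4-fluorophenyl in place of 2-fluorophenyl on a double-bonded chain carbon bound to a double-bonded ring carbon. This is the same change, at the same place, as that from compound 1 to compound 3, now made on the core of compound 2.

The expected step is a 1.7-fold higher number from compound 2 to compound 4 (0.24 log units; within the scatter) because the same change on the other core produced a 1.8-fold higher number from compound 1 to compound 3 (0.26 log units; within the scatter), a step that stayed within the scatter. The expectation rests on that single precedent alone, and any step of similar size would be consistent with it. Compound 4 is therefore expected to give about 19000 nM in this assay, estimated to fall between 9000 nM and 40000 nM.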

Compound 4, half-maximal inhibitory concentration: 20900 nM
Beside the measured number, compound 4's estimate is 1.1-fold (0.04 log units) below it, within the range that was stated.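

In this assay, 4-fluorophenyl in place of 2-fluorophenyl gives a 1.9-fold higher number from compound 2 to compound 4 (0.28 log units; within the scatter), so compound 2 and compound 4 cannot be separated on this read-out. Set beside the earlier step, the same change reads alike on the two cores: the same change on two cores in this assay, a 1.8-fold higher number (0.26 log units; within the scatter) from compound 1 to compound 3 and a 1.9-fold higher number (0.28 log units; within the scatter) from compound 2 to compound 4, 1.0-fold (0.01 log units) apart, within the scatter of two such steps This shows that the two steps agree in size, but each lies within the scatter on its own, so the agreement does not establish that the change has any real effect on the number, and two cores give no rule for other cores in the series.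

From the compounds shown here alone, whether the same change gives a step of similar size with an amine or a carboxylic acid on the other phenyl group, in place of the nitrile or the methoxy groups, remains open. Also open, going by these compounds, is whether any step beyond the scatter appears when the fluorophenyl group gives way to a group without fluorine, such as a pyridyl group or a longer chain.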